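A few compounds are considered here, and "the series" means these few. Any claim that something is new, unique, unknown or untested is made for them only; others in the source may bear on it.

Compound 1 `COc1ccc(-c2noc(-c3ccccc3)n2)cc1OC1CCCC1` stands at the edge of what a functional assay on MCF7 cells (Homo sapiens) for antiproliferative activity, read by MTT assay, with a stated time of 24 h (on this read-out lower numbers stand for stronger inhibition and higher numbers for weaker inhibition), can report: compound 1 gives > 1000000 nM, which is a limit and not a number. Compound 2 `COc1ccc(-c2noc(Cc3c[nH]c4ccccc34)n2)cc1OC1CCCC1` gives > 1000000 nM, also a limit. Compound 1 and compound 2 therefore share (the limit of > 1000000 nM in this assay, at which 2 of the 2 values shown sit). Compound 3 `COc1ccc(-c2noc(-c3ccc(O)cc3)n2)cc1OC1CCCC1` changes phenyl to 4-hydroxyphenyl, with hydroxy in place of hydrogen on an aromatic carbon. On that ground, the expected step in this assay is a number no higher from compound 1 to compound 3 (the limit leaves the size open), none beyond the usual scatter. For compound 3 the estimated value is 1000000 nM, within an expected range of 300000 nM to 3000000 nM.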

Compound 3, half-maximal inhibitory concentration: 390 nM
Beside the measured number, compound 3's estimate is 2600-fold (3.41 log units) above it, outside the stated range (below it).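

On the phenyl ring of compound 1, a single hydroxy in place of hydrogen on an aromatic carbon, para to a large group, brings the series to a measurable number in this assay: the change gives an at least 2500-fold lower number from compound 1 to compound 3 (3.40 log units; beyond the scatter). Within the data shown here, this is the first sign that this position responds to a change, since until now the values showed only a limit: the limit of > 1000000 nM in this assay, at which 2 of the 3 values shown sit. The value of compound 1 is a limit, so the step gives only a minimum size. Still open, from the compounds shown here alone, is whether the hydroxy is needed here or whether an amine, a methoxy or a carboxylic acid at the same place would also give a measurable number.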